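The source may report more compounds than this note shows. Statements on the series, on what has been measured and on what is new or still open speak of the compounds shown alone.

The three compounds measured so far, with their values in a functional assay on the whole organism (Tail, strain ICR) with Mus musculus as the target, in the tail flick test, with a stated time of 120 min, at a dose of 25 umol/kg by the oral route; a lower number here means a weaker effect, a higher number a stronger effect of the compound at the dose given:

Compound 1, `NCCCC[C@H](NC(=O)CN(c1nc(Cl)nc2[nH]cnc12)C1CC1)C(=O)OCc1ccccc1`: 16.8%
Compound 2, `CC[C@H](C)[C@H](NC(=O)CN(c1ncnc2c1ncn2C1CCCCO1)C1CC1)C(=O)OCc1ccccc1`: 20.4%
Compound 3, `O=C(O)C[C@H](NC(=O)CN(c1nc(Cl)nc2[nH]cnc12)C1CC1)C(=O)O`: 22%

All three share the same core, and all three sit low in this assay. Compound 1 gives the smallest of the three numbers, but compound 2 and compound 3 both lie within the usual scatter of it, so the three values cannot be told apart: they describe one weak level of effect rather than a ranking.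

The next compound, compound 4, `NC(=O)CC[C@H](NC(=O)CN(c1nc(Cl)nc2[nH]cnc12)C1CC1)C(=O)OCc1ccccc1`, has not yet been measured. It differs from compound 1 in one place only: carbamoyl in place of 2-aminoethyl on a saturated chain carbon, three bonds along the chain from an amide-type nitrogen and a carbonyl carbon. Everything else, the core and the ester end of the molecule, is kept.

Among the measured compounds shown here, no pair of measured compounds differs in just one place, so there is no measured step of this kind to lean on. For the measured compounds named here, with every number so far at the same low level, the expectation is that compound 4 stays there too, and the step of a number 1.2 percentage points higher from compound 1 to compound 4 (within the scatter) is expected to fall within the scatter rather than beyond it. For compound 4 the estimated activity is 18%, with a range from 8% to 30%.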

Compound 4, a percentage reported as activity, at one dose (the size of the read-out at that dose, not a potency): 36%
Estimate against measurement, compound 4: 18 percentage points below; the measured number lies above the stated range.
By their numbers in this assay, from the lowest: compounds 1, 2 and 3 (each within the scatter of the next); then compound 4.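

In this assay, among the compounds shown here, the change gives the first step between two compounds that differ in one place, a number 19.2 percentage points higher from compound 1 to compound 4 (beyond the scatter), which shows that the group on this saturated chain carbon, three bonds along the chain from an amide-type nitrogen and a carbonyl carbon, can shift the read-out while the core and the ester end stay the same. The step also arises between two groups that match in their counts of heavy atoms, hydrogen-bond donors and hydrogen-bond acceptors, and that both carry no net charge, so those counts alone do not separate 2-aminoethyl from carbamoyl; what differs is that carbamoyl holds an oxygen and a double bond. Nothing measured here explains why the read-out moves with this change.

This is a single pair at a single dose, so it cannot yet show whether the carbamoyl itself matters or whether another group at this carbon, such as a hydroxyl, a sulfonamide or a methyl ether, would do the same. It also leaves open how far the chain length counts, since a longer chain ending in carbamoyl does not appear among these compounds.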